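Chloro to Methyl on the Benzyl Ether of a Shared Core

The source may hold more compounds than are shown below. What is called first, only, known or untested is meant among the compounds shown, and "the series" means these compounds.

Three analogues built on one core were measured in an assay on CHO cells for displacement of a labelled ligand from Alpha-1D adrenergic receptor (Homo sapiens); a lower number here means a stronger inhibitor, a higher number a weaker inhibitor. Compound 1 `COc1cccc(OC)c1OCCNCCOc1ccccc1OCc1ccccc1` gives 0.0676 nM. Compound 2 `COc1cccc(OC)c1OCCNCCOc1ccccc1OCc1ccccc1Cl` gives 0.251 nM, and compound 3 `COc1cccc(OC)c1OCCNCCOc1ccccc1OCc1ccccc1C` gives 0.126 nM. Compound 2 has the highest number of the three: the step of a 3.7-fold higher number from compound 1 to compound 2 (0.57 log units; beyond the scatter) lies beyond the scatter, whereas a 2.0-fold lower number from compound 2 to compound 3 (0.30 log units; within the scatter) and a 1.9-fold higher number from compound 1 to compound 3 (0.27 log units; within the scatter) both remain within it.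

Compound 4 `COc1cccc(OC)c1OCCNCCOc1ccccc1OCc1cccc(C)c1` has not yet been measured. It differs from compound 2 by 3-methylphenyl in place of 2-chlorophenyl on a saturated chain carbon bound to an oxygen on an aromatic ring; cut one bond further out, the same difference reads 2-chlorobenzyl to 3-methylbenzyl.

For the measured compounds named here, the measured step that bears most directly on this change is the one from compound 2 to compound 3, a methyl in place of chloro on an aromatic carbon, which was a 2.0-fold lower number from compound 2 to compound 3 (0.30 log units; within the scatter). Losing the chloro also recalls a 3.7-fold higher number from compound 1 to compound 2 (0.57 log units; beyond the scatter) read in reverse. Going by the values given here, no measured compound carries a 3-methylphenyl group, so that part of the change rests on no measured step.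

The step of a 2.3-fold lower number from compound 2 to compound 4 (0.36 log units; beyond the scatter) is expected to be modest and toward a lower number. Compound 4 is estimated at 0.11 nM, within a range from 0.04 nM to 0.3 nM.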

Compound 4, inhibition constant: 0.2 nM
Compound 4: middle estimate off by 1.8-fold (0.26 log units), on the low side; measured number inside the range.
By their numbers in this assay, from the lowest: compounds 1, 3, 4 and 2 (each within the scatter of the next, the first and the last beyond it).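

In this assay the placement of the methyl now has a reading, and the step of a 1.6-fold higher number from compound 3 to compound 4 (0.20 log units; within the scatter) shows that 3-methylphenyl in place of 2-methylphenyl on this saturated chain carbon does not separate the two compounds. The step of a 1.3-fold lower number from compound 2 to compound 4 (0.10 log units; within the scatter) likewise leaves 3-methylphenyl and 2-chlorophenyl apart by no more than repeated measurements would be, so this swap of both group and placement does not register here. Against the unsubstituted phenyl of the shared core, the step of a 3.0-fold higher number from compound 1 to compound 4 (0.47 log units; beyond the scatter) puts compound 4 with compound 2 as a second substituted analogue beyond the scatter from compound 1, while compound 3 goes against that pattern by staying within it, as the step of a 1.9-fold higher number from compound 1 to compound 3 (0.27 log units; within the scatter) shows.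

On these data alone, whether a 3-chlorophenyl group would track 3-methylphenyl at this carbon remains open, as does the effect of a methoxy group, an amine or a carboxylic acid on the same ring. Whether any substituent on this ring could reach a number below that of compound 1 also stays unanswered by these four compounds.

No evidence is available here to explain why these numbers fall as they do.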